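Swapping methyl for nitro on the aromatic ring

This account rests on a few compounds, and the source may have more. Where it says the series, first, only, none or still open, it means among the compounds named here.

Values in a functional assay (muscle tissue) with Cavia porcellus as the target (on this read-out higher numbers stand for an effect only at larger amounts of compound and lower numbers for an effect already at smaller amounts), stand beside each compound.

Compound 1 `COC(=O)C1=C(C)N=C(C)/C(=C(\O)OC)C1c1ccccc1N` gives 39800 nM in this series
Compound 2 `COC(=O)C1=C(C)N=C(C)/C(=C(\O)OC)C1c1ccc(F)cc1` gives 129 nM in this series
Compound 3 `COC(=O)C1=C(C)N=C(C)/C(=C(\O)OC)C1c1cccc(C)c1` gives 110 nM in this series

Compound 3 sits at the low end of these numbers, level with compound 2 and far from compound 1. The two measured steps that leave the 2-aminophenyl are large (a 310-fold lower number from compound 1 to compound 2 (2.49 log units; beyond the scatter)) and (a 360-fold lower number from compound 1 to compound 3 (2.56 log units; beyond the scatter)). The exchange between the two other aryl groups stays within the scatter (a 1.2-fold lower number from compound 2 to compound 3 (0.07 log units; within the scatter)).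

Compound 4 `COC(=O)C1=C(C)N=C(C)/C(=C(\O)OC)C1c1cccc([N+](=O)[O-])c1` has nitro in place of methyl on an aromatic carbon and keeps the shared core. For the measured compounds named here, it carries no 2-aminophenyl, so the large steps offer little guide, and no measured compound holds a nitro group. The expectation in this assay is therefore a moderate step to a lower number, estimated as a 2.8-fold lower number from compound 3 to compound 4 (0.44 log units; beyond the scatter) and held loosely. In this assay compound 4 is expected at 40 nM (estimated range 5 nM to 200 nM).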

Compound 4, half-maximal effective concentration: 3.98 nM
Compound 4: middle estimate off by 10-fold (1.00 log units), on the high side; the whole stated range lies above it.
By their numbers in this assay, from the lowest: compound 4; then compounds 3 and 2 (each within the scatter of the next); then compound 1.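

On the aromatic carbon meta to a large group, the change from methyl to nitro gives a 28-fold lower number from compound 3 to compound 4 (1.44 log units; beyond the scatter) in this assay. For the compounds shown here, until now, the only large steps had led away from the 2-aminophenyl, and the exchange between the 3-methylphenyl and the 4-fluorophenyl had stayed within the scatter, so the aryl group could have seemed to matter little once the 2-aminophenyl was gone. This result shows that a single exchange on the aromatic ring can also shift the number strongly among aryl groups without that amine, though nothing at hand accounts for the size of this step.

The compounds shown leave open whether a nitrile or a trifluoromethyl on the same carbon would follow nitro or stay level with methyl. They also leave open whether nitro would give a similar number on another carbon of the ring.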